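The source may hold more compounds than are shown below. What is called first, only, known or untested is meant among the compounds shown, and "the series" means these compounds.

In a functional assay on B16-F10 cells (Mus musculus) for cytotoxicity (a lower number here means a stronger inhibitor, a higher number a weaker inhibitor), compound 1 (`O=c1oc2ccccc2c2nc3c(ccc4cc[nH]c43)c(-c3ccc(O)cc3)c12`) gives 70700 nM and compound 2 (`Cc1ccc(-c2c3ccc4cc[nH]c4c3nc3c2c(=O)oc2ccccc23)cc1`) gives 70700 nM as well, so compound 2 stands level with compound 1 at the digits shown. Compound 3 (`O=c1oc2ccccc2c2nc3c(ccc4cc[nH]c43)c(-c3ccccc3)c12`) shares their core and differs from compound 2 by one small edit, hydrogen in place of methyl on an aromatic carbon, which turns 4-methylphenyl into phenyl. For the measured compounds named here, only one measured step bears on this. It is also a swap of a small group on an aromatic carbon, methyl in place of hydroxy, and it amounted to no change at the digits printed from compound 1 to compound 2 (within the scatter) and nothing more. A single step is thin evidence, but it offers no reason to expect a large shift in this assay or to favour a direction. The expected change is therefore within the scatter, an estimated no change at the digits printed from compound 2 to compound 3 (within the scatter) for this edit. Compound 3 is estimated at 70700 nM within an expected range of 35000 nM to 130000 nM in this read-out.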

Compound 3, half-maximal inhibitory concentration: 70700 nM
Compound 3: the middle estimate sits on the measured number at the digits printed; the measured number falls inside the stated range.
By their numbers in this assay, from the lowest: compounds 1, 2 and 3 (each within the scatter of the next).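

In this assay, taking the methyl off 4-methylphenyl to leave phenyl gives no change at the digits printed from compound 2 to compound 3 (within the scatter), so this aromatic carbon, para to a large group, reads the same with hydrogen as with methyl. Hydrogen in place of hydroxy gives no change at the digits printed from compound 1 to compound 3 (within the scatter), which adds the bare phenyl ring as a reference point: neither hydroxy nor methyl separates from it, whereas the earlier pair could only be compared with each other. Nothing available accounts for this flat reading.

The compounds shown leave open whether an amine, a carboxylic acid or a longer chain such as butyl on this same carbon would move the number. They also leave open whether edits elsewhere on the shared core would do so.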